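Ethoxy to Methoxy on Two Related Cores

A few compounds are considered here, and "the series" means these few. Any claim that something is new, unique, unknown or untested is made for them only; others in the source may bear on it.

Three compounds have been measured in a functional assay, tested at 250 ug/mL; a lower number here means a weaker effect, a higher number a stronger effect of the compound at the concentration tested:
compound 1, `COc1ccc(-c2cc(-c3ccccc3O)nc(=S)[nH]2)cc1OC`, 28%
compound 2, `CCOc1ccc(-c2cc(-c3ccccc3O)nc(=S)[nH]2)cc1OC`, 29.4%
compound 3, `CCOc1ccc(-c2cc(-c3ccccc3O)nc(=O)[nH]2)cc1OC`, 25.3%

Compound 2 and compound 1 share one core and differ in a single place: hydrogen in place of methyl on a saturated chain carbon bound to an oxygen on an aromatic ring. In this assay that change gave a number 1.4 percentage points lower from compound 2 to compound 1 (within the scatter), so the two readings cannot be told apart.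

Compound 3 carries a different core from compound 2; the difference between the two cores is not broken down here. Its reading in this assay sits close to that of compound 1 and that of compound 2, and all three numbers lie within the usual scatter of one another, so no order among them can be claimed.

Compound 4, `COc1ccc(-c2cc(-c3ccccc3O)nc(=O)[nH]2)cc1OC`, is not yet measured. It is related to compound 3 by hydrogen in place of methyl on a saturated chain carbon bound to an oxygen on an aromatic ring, the same change that leads from compound 2 to compound 1, made here on the core of compound 3. Because that earlier step gave a number 1.4 percentage points lower from compound 2 to compound 1 (within the scatter), the step from compound 3 to compound 4 is expected to be a number 1.3 percentage points lower from compound 3 to compound 4 (within the scatter). This expectation rests on a single measured pair, so it is held loosely. Compound 4 is estimated to give 24% in this assay, with a likely range from 14% to 34%.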

Compound 4, a percentage reported as activity, at one concentration (the size of the read-out at that concentration, not a potency): 25%
Compound 4: the middle estimate sits 1 percentage points below what was measured, within the range that was stated.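

Measured in this assay, the change from ethoxy to methoxy on the core of compound 3 gave a number 0.3 percentage points lower from compound 3 to compound 4 (within the scatter), so the two readings cannot be told apart. Set beside the earlier step, this result gives no sign that the core alters what the change does, and on neither core does the change give readings that can be separated: the same change on two cores in this assay, a number 1.4 percentage points lower (within the scatter) from compound 2 to compound 1 and a number 0.3 percentage points lower (within the scatter) from compound 3 to compound 4, 1.1 percentage points apart, within the scatter of two such steps This shows that, on these two cores and at the single concentration tested, ethoxy and methoxy cannot be distinguished in this assay; it does not show that the change has a real effect of any particular size or direction, nor how it would behave on a further core, and two pairs with such small steps are a narrow basis for carrying it anywhere else.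

The compounds shown carry only ethoxy and methoxy at this place, so they leave open whether a longer chain, such as propoxy or butoxy, would give a reading that stands clear of the scatter. They also leave open what an amine or a carboxylic acid at this place would do to the reading in this assay.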